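The source may hold more compounds than are shown below. What is called first, only, known or untested is meant among the compounds shown, and "the series" means these compounds.

In a functional assay on Vas deferens for antagonist activity at Alpha-1A adrenergic receptor (Rattus norvegicus) (on this read-out lower numbers stand for lower potency and higher numbers for higher potency (the scale is a negative logarithm)), compound 1, `COc1cccc(OC)c1OCCNCCOc1ccccc1OCc1ccccc1`, gives 8.39. Compound 2, `COc1cccc(OC)c1OCCNCCOc1ccccc1OCc1ccc(Cl)cc1`, gives 8.17 in this assay, and compound 3, `COc1cccc(OC)c1OCCNCCOc1ccccc1OCc1ccccc1[N+](=O)[O-]`, gives 8.2. The three differ only in the substituent on the benzyl ring: a number 0.22 log units lower from compound 1 to compound 2 (within the scatter) and a number 0.19 log units lower from compound 1 to compound 3 (within the scatter), while a number 0.03 log units higher from compound 2 to compound 3 (within the scatter). On the numbers shown, compound 2 sits at the low end of the three, but each of the two other values lies within the scatter of it, so the three compounds are not told apart by this assay.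

Compound 4, `COc1ccccc1COc1ccccc1OCCNCCOc1c(OC)cccc1OC`, is reached from compound 2 by the change (2-methoxyphenyl in place of 4-chlorophenyl on a saturated chain carbon bound to an oxygen on an aromatic ring).

Among the measured compounds shown here, the steps that bear on this change are the ones where the benzyl ring substituent was varied from compound 1 to compound 2 and to compound 3 and between compound 2 and compound 3, and all of them stayed within the scatter. A methoxy group on the benzyl ring has not itself been tested here, so the step is expected to be a number 0.13 log units higher from compound 2 to compound 4 (within the scatter), with no change beyond the scatter. Compound 4 is therefore estimated at 8.3 in this assay, with a likely range from 7.8 to 8.8.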

Compound 4, negative logarithm of the antagonist equilibrium constant: 8.53
Estimate against measurement, compound 4: 0.23 log units below, within the range that was stated.
By their numbers in this assay, from the lowest: compounds 2, 3, 1 and 4 (each within the scatter of the next, the first and the last beyond it).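

In this assay, among the compounds shown here, changes on the benzyl ring now go beyond the scatter for the first time, though only modestly: a number 0.36 log units higher from compound 2 to compound 4 (beyond the scatter), and a number 0.33 log units higher from compound 3 to compound 4 (beyond the scatter). The unsubstituted ring does not separate from the methoxy-bearing one, however, with a number 0.14 log units higher from compound 1 to compound 4 (within the scatter), so the methoxy group can be told apart only from the chloro and nitro compounds, and those two in turn stay within the scatter of compound 1. The four compounds thus show that this ring accepts all of these changes with only modest steps, and nothing shown gives a reason for the steps that do pass the scatter.

The change from compound 2 to compound 4 swaps both the group and where it sits on the ring, so these compounds cannot say how much of the step belongs to each. Also open, going by these compounds, is whether an amine or a carboxylic acid on this ring, or a longer chain in place of the methoxy, would keep the number in the same region.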